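Shortening the pyrrolidine-bearing chain

A few compounds are considered here, and "the series" means these few. Any claim that something is new, unique, unknown or untested is made for them only; others in the source may bear on it.

In a functional assay on BCG823 cells (Homo sapiens) for antiproliferative activity, read by MTT assay, with a stated time of 48 h (on this read-out lower numbers stand for stronger inhibition and higher numbers for weaker inhibition), compound 1 (`O=c1cc(-c2ccccc2)oc2cc(O)c(OCCCN3CCCCC3)c(O)c12`) gives 60900 nM, compound 2 (`O=c1cc(-c2ccccc2)oc2cc(O)c(OCCCCN3CCCCC3)c(O)c12`) gives 52700 nM and compound 3 (`O=c1cc(-c2ccccc2)oc2cc(O)c(OCCCCN3CCCC3)c(O)c12`) gives 86400 nM. Compound 3 stands within the scatter of both others: a 1.4-fold higher number from compound 1 to compound 3 (0.15 log units; within the scatter) and a 1.6-fold higher number from compound 2 to compound 3 (0.21 log units; within the scatter).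

Compound 4 (`O=c1cc(-c2ccccc2)oc2cc(O)c(OCCCN3CCCC3)c(O)c12`) differs from compound 3 as follows: pyrrolidin-1-yl in place of (pyrrolidin-1-yl)methyl on a saturated chain carbon, three bonds along the chain from an oxygen on an aromatic ring. Pyrrolidin-1-yl thus takes the place of (pyrrolidin-1-yl)methyl on a saturated chain carbon, three bonds along the chain from an oxygen on an aromatic ring, so that 4-(pyrrolidin-1-yl)butyl becomes 3-(pyrrolidin-1-yl)propyl.

Going by the values given here, the closest precedent is the same chain difference with piperidin-1-yl in place of pyrrolidin-1-yl, read in the opposite direction: a 1.2-fold lower number from compound 1 to compound 2 (0.06 log units; within the scatter). The ring exchange on the longer chain also stays within the scatter: a 1.6-fold higher number from compound 2 to compound 3 (0.21 log units; within the scatter). Among the compounds with values here, with only this one chain pair available, the precedent is thin. The estimated step is a 1.1-fold lower number from compound 3 to compound 4 (0.03 log units; within the scatter), and nothing beyond the scatter is expected in this assay. For compound 4 the expected value is 80000 nM, with an estimated range of 48000 nM to 135000 nM.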

Compound 4, half-maximal inhibitory concentration: > 100000 nM
Compound 4: a limit, no number (the forecaster's own chance of this, stated with the estimate: 10%); at least 1.2-fold (0.09 log units) between middle value and limit.
By their numbers in this assay, from the lowest: compounds 2, 1 and 3 (each within the scatter of the next). At a limit, above all of these: compound 4.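

Compound 4 gives > 100000 nM in this assay, a limit and not a number, and it is the only compound of the four shown to end at a limit with 3-(pyrrolidin-1-yl)propyl at this position. The steps to it can be read only as floors, an at least 1.1-fold higher number from compound 3 to compound 4 (0.06 log units; that floor lies within the scatter) and an at least 1.6-fold higher number from compound 1 to compound 4 (0.21 log units; that floor lies within the scatter) and an at least 1.8-fold higher number from compound 2 to compound 4 (0.27 log units; that floor lies within the scatter) so none shows a real change from the other compounds. Exchanging piperidin-1-yl for pyrrolidin-1-yl may or may not cost the same on both chains: the same change on two cores in this assay, a 1.6-fold higher number (0.21 log units; within the scatter) from compound 2 to compound 3 and an at least 1.6-fold higher number (0.21 log units; that floor lies within the scatter) from compound 1 to compound 4; the limit leaves it open whether they differ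

On these data alone, how far compound 4 lies past its limit stays open, and with it whether shortening the chain matters at all with pyrrolidin-1-yl. Also open, as far as these compounds go, is how 2-(pyrrolidin-1-yl)ethyl, a longer chain or a morpholine ring would read at this position.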